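Removing a methyl from an oxygen: a small step repeated

The source may report more compounds than this note shows. Statements on the series, on what has been measured and on what is new or still open speak of the compounds shown alone.

Of the compounds shown here, three have been tested in a functional assay on PC-3 cells (Homo sapiens) for antiproliferative activity, read by MTT assay, with a stated time of 96 h; a higher number here means a weaker inhibitor of growth, a lower number a stronger inhibitor of growth. Compound 1 `COc1cccc2ccc(Nc3cc(C)ccn3)nc12` gives 3820 nM. Compound 3 `Cc1ccnc(Nc2ccc3cccc(O)c3n2)c1` differs from compound 1 only by hydrogen in place of methyl on an oxygen on an aromatic ring; in this assay compound 3 gives 5840 nM, and the step is a 1.5-fold higher number from compound 1 to compound 3 (0.18 log units; within the scatter), so these two compounds cannot be told apart in this assay. Compound 2 `COc1ccc(Cl)c2ccc(Nc3ccccn3)nc12` carries a different core, and the difference between the core of compound 1 and the core of compound 2 is not broken down here; in this assay compound 2 gives 29200 nM, the highest of the three numbers, and it stands beyond the scatter from both compound 1 and compound 3.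

Compound 4 `Oc1ccc(Cl)c2ccc(Nc3ccccn3)nc12` has not yet been measured. It is related to compound 2 exactly as compound 3 is to compound 1: the change is hydrogen in place of methyl on an oxygen on an aromatic ring, on a place described in the same words in both pairs. Among the compounds with values here, the only measured example of this change, the step from compound 1 to compound 3, stayed within the scatter. Because the step of a 1.5-fold higher number from compound 1 to compound 3 (0.18 log units; within the scatter) was so small, compound 4 is expected to lie close to compound 2, with a step of about a 1.3-fold higher number from compound 2 to compound 4 (0.11 log units; within the scatter). On that basis the estimate for compound 4 in this assay is 38000 nM, with a likely range from 15000 nM to 95000 nM.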

Compound 4, concentration for 50% growth inhibition: 1290 nM
Beside the measured number, compound 4's estimate is 29-fold (1.47 log units) above it; measured number below the stated range.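

In this assay, replacing methoxy with hydroxy on the core of compound 2 gives a 23-fold lower number from compound 2 to compound 4 (1.35 log units; beyond the scatter), so on this core a very small edit comes with a large gain in growth inhibition. The same edit does not behave alike on the two cores: the same change on two cores in this assay, a 1.5-fold higher number (0.18 log units; within the scatter) from compound 1 to compound 3 and a 23-fold lower number (1.35 log units; beyond the scatter) from compound 2 to compound 4, 35-fold (1.54 log units) apart, beyond the scatter of two such steps. This shows that the outcome of the change on one core cannot simply be carried over to another core in this series, but two pairs cannot show which feature of the cores decides the outcome, or how the change would behave on a third core.

The compounds shown leave open which part of the difference between the core of compound 1 and the core of compound 2 matters, since no pair here separates those parts. Also open, going by these compounds, is what other groups on that same oxygen, such as an ethyl group or a longer chain, or an amine in place of the hydroxy, would do on each core.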